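The source may hold more compounds than are shown below. What is called first, only, known or untested is meant among the compounds shown, and "the series" means these compounds.

Working notes on the series.

Compound 1 `O=C(N/N=C/c1ccc(O)c(Br)c1)Nc1ccc(Oc2ccnc3[nH]ccc23)c(F)c1` gives 9250 nM in a functional assay on A549 cells (Homo sapiens) for antiproliferative activity, read by MTT assay, with a stated time of 72 h; a lower number here means a stronger inhibitor, a higher number a weaker inhibitor. Compound 2 `O=C(N/N=C/c1cc(Br)c(O)c(Br)c1)Nc1ccc(Oc2ccnc3[nH]ccc23)c(F)c1` differs from compound 1 by bromo in place of hydrogen on an aromatic carbon; in this assay compound 2 gives 16200 nM, so that the step of a 1.8-fold higher number from compound 1 to compound 2 (0.24 log units; within the scatter) is recorded. Compound 3 `O=C(N/N=C/c1ccccc1)Nc1ccc(Oc2ccnc3[nH]ccc23)cc1` gives 17200 nM in this assay; the difference between the core of compound 3 and the core of compound 1 is not broken down here.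

Compound 4 `O=C(N/N=C/c1ccc(Br)cc1)Nc1ccc(Oc2ccnc3[nH]ccc23)cc1` is not yet measured. It differs from compound 3 by bromo in place of hydrogen on an aromatic carbon. This is the same kind of change as that from compound 1 to compound 2, but not the same: in compound 2 the entering bromo sits ortho to a hydroxy group, meta to a bromo group and meta to a large group, whereas in compound 4 it sits para to a large group.

For compound 4 the step of a 1.2-fold higher number from compound 3 to compound 4 (0.09 log units; within the scatter) in this assay is expected, resting on the step of a 1.8-fold higher number from compound 1 to compound 2 (0.24 log units; within the scatter) seen for the one occurrence of this kind of change, with the caveat that the surroundings of the place are not the same. Compound 4 is therefore estimated at 21000 nM in this assay, between 8000 nM and 55000 nM.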

Compound 4, half-maximal inhibitory concentration: 640 nM
Estimate against measurement, compound 4: 33-fold (1.52 log units) above, and the stated range ends above it.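

In this assay the new step is a 27-fold lower number from compound 3 to compound 4 (1.43 log units; beyond the scatter), which is large, whereas the earlier step with the same change lies within the scatter. Bromo in place of hydrogen on an aromatic carbon therefore cannot be carried from one core to another in this series as a fixed increment: the same change on two cores in this assay, a 1.8-fold higher number (0.24 log units; within the scatter) from compound 1 to compound 2 and a 27-fold lower number (1.43 log units; beyond the scatter) from compound 3 to compound 4, 47-fold (1.67 log units) apart, beyond the scatter of two such steps. This does not show which difference between the two pairs separates the steps, since the pairs differ both in their cores and in the surroundings of the place where the bromo enters, and with one step on each side it gives no general rule for either core.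

The compounds shown leave open whether the 4-bromophenyl group would give a comparable number on the core of compound 1, which would separate the contribution of the core from that of the place. They also leave open whether a chloro, methyl or methoxy group in the place of this bromo would give a step of like size from compound 3.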